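Vinyl in Place of Hydrogen on a Shared Core

A few compounds are considered here, and "the series" means these few. Any claim that something is new, unique, unknown or untested is made for them only; others in the source may bear on it.

In a functional assay on Jurkat cells (Homo sapiens) for cytotoxicity (on this read-out higher numbers stand for weaker inhibition and lower numbers for stronger inhibition), compound 2 `O=C1C=C(CO)[C@H](O)[C@H]2O[C@@H]12` gives only a limit, > 80000 nM. Compound 3 `C/C=C/C1=C(CO)[C@H](OC)[C@H]2O[C@H]2C1=O` likewise stops at a limit, > 80000 nM. Compound 1 `C/C=C/C1=C(CO)[C@@H](O)[C@@H]2O[C@@H]2C1=O` gives a number in this assay, 60000 nM. Compound 2 thus stands at the limit of > 80000 nM in this assay, at which 2 of the 3 values shown sit. Compound 4 `C=CC1=C(CO)[C@H](O)[C@H]2O[C@H]2C1=O` has not yet been measured; it differs from compound 2 by vinyl in place of hydrogen on a double-bonded ring carbon. For the measured compounds named here, no single-change step between measured compounds is available, so the size of the step in this assay can only be expected, not read off. Because compound 1 gives 60000 nM, compound 4 is expected to remain weak. Compound 4 is estimated at 70000 nM, between 30000 nM and 150000 nM. The expected step of an at least 1.1-fold lower number from compound 2 to compound 4 (0.05 log units; that floor lies within the scatter) is judged to lie within the scatter.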

Compound 4, half-maximal inhibitory concentration: > 80000 nM
Compound 4: only a limit was reported; the forecaster's own chance of this, stated with the estimate: 55%; middle value at least 1.1-fold (0.05 log units) from the limit.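

For the compounds shown here, compound 2 and compound 4 both stop at a limit in this assay, so no step between them can be read. The compounds shown leave open whether vinyl in place of hydrogen changes this read-out at all.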